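A Methyl Group Added to Compound 2

This account rests on a few compounds, and the source may have more. Where it says the series, first, only, none or still open, it means among the compounds named here.

In an ADME assay on L02 cells (Homo sapiens) for cytotoxicity, read by MTT assay, with a stated time of 24 h (a lower number here means that less compound is tolerated, a higher number that more compound is tolerated), compound 2 `O=c1[nH]cc(S(=O)(=O)Nc2cccc(-c3cn(-c4ccccc4)nn3)c2)c(=O)[nH]1` gives > 100000 nM as a limit of the assay and not a number. Compound 1 `O=c1[nH]cc(S(=O)(=O)Nc2ccccc2-c2cn(-c3ccccc3Cl)nn2)c(=O)[nH]1` gives 22800 nM in this assay as a true measured number. Compound 3 `Cc1cccc(-n2cc(-c3cccc(NS(=O)(=O)c4c[nH]c(=O)[nH]c4=O)c3)nn2)c1` differs from compound 2 by a single change methyl in place of hydrogen on an aromatic carbon with methyl in place of hydrogen on an aromatic carbon. Among the measured compounds shown here, no measured step yet shows what this change does, so the expected step of a number no higher from compound 2 to compound 3 (the limit leaves the size open) is small and stays within the usual scatter. In this assay compound 3 is expected near 100000 nM with an estimated range from 40000 nM to 250000 nM around that value.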

Compound 3, half-maximal cytotoxic concentration: 28300 nM
Beside the measured number, compound 3's estimate is 3.5-fold (0.55 log units) above it; measured number outside the range, below it.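

In this assay, among the compounds shown here, this is the first measured step at this position, and methyl in place of hydrogen on an aromatic carbon does not leave the result unchanged: the data give an at least 3.5-fold lower number from compound 2 to compound 3 (0.54 log units; beyond the scatter). A single added carbon on the phenyl ring is therefore enough for less compound to be tolerated, and compound 3 gives a true number. The full size of the step stays open, since compound 2 carries only a limit of the assay: the limit of > 100000 nM in this assay, at which 1 of the 3 values shown sits.

From the compounds shown here alone, it remains open whether an ethyl chain, an amine or a carboxylic acid at this place would give a similar step. Going by these compounds, it also remains open whether methyl would do the same elsewhere on this ring.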